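Dichlorophenyl swap on a dimethoxybenzylidene cyclohexanone core

This account rests on a few compounds, and the source may have more. Where it says the series, first, only, none or still open, it means among the compounds named here.

The series is read in a functional assay on A549 cells (Homo sapiens) for cytotoxicity, read by MTT assay, with a stated time of 72 h; a lower number here means a stronger inhibitor, a higher number a weaker inhibitor. Compound 1 `COc1cccc(/C=C2\CCC/C(=C\c3cccc(Cl)c3Cl)C2=O)c1OC` carries a 2,3-dichlorophenyl group on the shared core. In this assay compound 1 gives > 20000 nM, which is a limit of the assay and not a number. Compound 2 `COc1cccc(/C=C2\CCC/C(=C\c3ccc(Cl)cc3Cl)C2=O)c1OC` differs from compound 1 by 2,4-dichlorophenyl in place of 2,3-dichlorophenyl on a double-bonded chain carbon bound to a double-bonded ring carbon. In this assay compound 2 gives > 20000 nM, again a limit of the assay. The step that the two limits leave unreadable from compound 1 to compound 2 therefore cannot be sized; both ends rest on (the limit of > 20000 nM in this assay, at which 3 of the 3 values shown sit).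

Compound 3 `COc1ccc(/C=C2\CCC/C(=C\c3cccc(Cl)c3Cl)C2=O)cc1OC` is built on the other core; the difference between the two cores is not broken down here. In this assay compound 3 gives > 20000 nM, which is a limit of the assay and not a number.

Compound 4 `COc1ccc(/C=C2\CCC/C(=C\c3ccc(Cl)cc3Cl)C2=O)cc1OC`, still to be measured, differs from compound 3 by 2,4-dichlorophenyl in place of 2,3-dichlorophenyl on a double-bonded chain carbon bound to a double-bonded ring carbon. Going by the values given here, the change is the same kind of change as the one made from compound 1 to compound 2, at the same place on the chain carbon. Among the compounds with values here, the only precedent for this change left both ends of the step at the limit, as the limit of > 20000 nM in this assay, at which 3 of the 3 values shown sit, shows, so no direction can be read from it. For compound 4 the step that the limit leaves unreadable from compound 3 to compound 4 is therefore expected to be near zero, with the result most likely sitting at the limit again. The estimated value for compound 4 in this assay is 30000 nM, spanning 12000 nM to 100000 nM, and the expectation rests on compound 3 giving > 20000 nM and on every measured member of the series sitting at the same limit.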

Compound 4, half-maximal inhibitory concentration: > 20000 nM
Compound 4: no number, only a limit (the forecaster's own chance of this, stated with the estimate: 85%); the middle value is on the limit's open side.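

Compound 4, like compound 3, gives only a limit of the assay and not a number in this assay, so the swap of 2,3-dichlorophenyl for 2,4-dichlorophenyl cannot be sized between compound 3 and compound 4: the limit of > 20000 nM in this assay, at which 4 of the 4 values shown sit.

The compounds shown leave open whether either dichlorophenyl group or either core makes any difference in this assay, since none of them gives a number there.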